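Furan-3-yl to 1H-pyrrol-2-yl on compound 2

A few compounds are considered here, and "the series" means these few. Any claim that something is new, unique, unknown or untested is made for them only; others in the source may bear on it.

Measured so far in an ADME assay on Vero cells (Chlorocebus sabaeus) for cytotoxicity, with a stated time of 7 days; a higher number here means that more compound is tolerated, a lower number that less compound is tolerated:
compound 1 (`Cc1ccc2[nH]c(C(=O)N3CC(=O)N(Cc4ccccc4)[C@@H](CN4CCC5(CCC5)CC4)C3)cc2c1`): 7800 nM
compound 2 (`COc1ccc2[nH]c(C(=O)N3CC(=O)N(Cc4ccoc4)[C@@H](Cc4ccccc4)C3)cc2c1`): > 10000 nM (a limit of the assay)

Compound 2 stands at the limit of > 10000 nM in this assay, at which 1 of the 2 values shown sits, so its place is a limit and not a number. Compound 3 (`COc1ccc2[nH]c(C(=O)N3CC(=O)N(Cc4ccc[nH]4)[C@@H](Cc4ccccc4)C3)cc2c1`) carries 1H-pyrrol-2-yl in place of furan-3-yl on a saturated chain carbon bound to an amide-type nitrogen in a ring. Among the measured compounds shown here, no measured step of this kind exists to go on. The expected change, a number no higher from compound 2 to compound 3 (the limit leaves the size open), is none beyond the scatter in this assay, in either direction. Compound 3 is estimated at 10000 nM, within an expected range of 6000 nM to 15000 nM, and it may again be reported only as a limit.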

Compound 3, half-maximal cytotoxic concentration: 15200 nM
Beside the measured number, compound 3's estimate is 1.5-fold (0.18 log units) below it, outside the stated range (above it).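

In this assay, among the compounds shown here, compound 2 gives > 10000 nM, a limit of the assay, and no step from it to compound 3 can be read. The compounds shown leave open whether, and how far, 1H-pyrrol-2-yl in place of furan-3-yl shifts this read-out.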